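The compounds below may be only part of what the source reports. "The series", "measured", "known", "first", "only" and "open" are said of these compounds alone.

Measured so far:
- compound 1 `C=C1C(=O)O[C@@H]2CC(C)=C([C@@H](C)CCCOC(C)=O)[C@@H](OC(=O)CN(CC)CC)[C@H]12` — 10700 nM
- compound 2 `C=C1C(=O)O[C@@H]2CC(C)=C([C@@H](C)CCCOC(C)=O)[C@@H](OC(=O)COc3ccc(C(=O)OCCC)cc3)[C@H]12` — 22900 nM

In a functional assay on HeLa cells (Homo sapiens) for cytotoxicity, read by sulforhodamine B assay, with a stated time of 72 h (a higher number here means a weaker inhibitor, a lower number a stronger inhibitor), compound 1 gives the lower of the two numbers; compound 2 sits higher by a margin beyond the scatter. Compound 3 `C=C1C(=O)O[C@@H]2CC(C)=C([C@@H](C)CCCOC(C)=O)[C@@H](OC(=O)c3ccccc3)[C@H]12` differs from compound 1 in one place: phenyl in place of (diethylamino)methyl on a carbonyl carbon, the ester at that position otherwise kept. Among the compounds with values here, no measured pair shows this change. A small step is expected, toward a lower number if anything, not clearly beyond the scatter: a 1.3-fold lower number from compound 1 to compound 3 (0.13 log units; within the scatter). Compound 3 is estimated at 8000 nM, with a range from 3000 nM to 25000 nM.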

Compound 3, half-maximal inhibitory concentration: 5190 nM
The estimate for compound 3 lay 1.5-fold (0.19 log units) above the measured number; the range from low to high includes it.
By their numbers in this assay, from the lowest: compound 3; then compound 1; then compound 2.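

In this assay, the carbonyl carbon of this ester responds to a change of group with the ester itself kept: phenyl in place of (diethylamino)methyl gives a 2.1-fold lower number from compound 1 to compound 3 (0.31 log units; beyond the scatter). The nitrogen of the (diethylamino)methyl group is therefore not required for the activity seen at this position. No measurement here explains the step.

On these data alone, it remains open whether a benzoyl carrying a methoxy or a carboxylic acid, or a cyclohexyl on the same carbonyl carbon, would move the number further. A shorter amine such as dimethylaminomethyl also leaves open how much the diethyl part contributes.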